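The source may report more compounds than this note shows. Statements on the series, on what has been measured and on what is new or still open speak of the compounds shown alone.

In an ADME assay on HEK293 cells (Homo sapiens) for cytotoxicity, read by fluorescence and resazurin assay, with a stated time of 48 h (on this read-out higher numbers stand for lower toxicity in this test and lower numbers for higher toxicity in this test), compound 1 `O=C(O)CC(O)/C=N/c1cc(Br)cc(Br)c1O` gives 104000 nM and compound 2 `O=C(O)CC(O)/C=N/c1cc(Cl)cc(Cl)c1O` gives 101000 nM so compound 2 stands within the scatter of compound 1. Compound 3 `O=C(O)CC(O)/C=N/c1cc(Cl)cc(Br)c1O` is unmeasured. Its difference from compound 2 is bromo in place of chloro on an aromatic carbon with bromo in place of chloro on an aromatic carbon, ortho to a hydroxy group. Going by the values given here, no single-place step has been measured, but compound 3 is expected to resemble compound 2 in this assay because compound 1 at 104000 nM and compound 2 at 101000 nM lie within the scatter of each other. The estimated 1.0-fold higher number from compound 2 to compound 3 (0.00 log units; within the scatter) stays inside that scatter. For compound 3 the estimated value is 102000 nM with 60000 nM to 170000 nM as the expected range.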

Compound 3, half-maximal cytotoxic concentration: 109000 nM
Compound 3: the middle estimate sits 1.1-fold (0.03 log units) below what was measured, and the stated range covers the measured number.
By their numbers in this assay, from the lowest: compounds 2, 1 and 3 (each within the scatter of the next).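

Bromo in place of chloro, ortho to a hydroxy group, can now be read as a single exchange in this assay: the step is a 1.1-fold higher number from compound 2 to compound 3 (0.03 log units; within the scatter) and stays within the scatter. The other halogen place also reads singly, with chloro in place of bromo giving a 1.0-fold higher number from compound 1 to compound 3 (0.02 log units; within the scatter) and likewise staying within the scatter, so neither exchange separates these compounds. No measured evidence here bears on the reason for this.

As far as these compounds go, whether an amine or a methoxy group at either place would read the same remains open. Also open, from the compounds shown here alone, is whether the core tolerates a hydrogen in place of either halogen.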